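One Added Methyl on Compound 1

A few compounds are considered here, and "the series" means these few. Any claim that something is new, unique, unknown or untested is made for them only; others in the source may bear on it.

In an ADME assay for permeability, using PAMPA, with a stated time of 4 h, at pH 7.4, tested at 100 uM (a higher number here means that the compound crosses the layer faster, a lower number that the compound crosses the layer more slowly), compound 1 (`Cc1nc2cc(-c3cccc(-c4ccccc4)c3)nn2c(-c2cc(F)c3c(c2C)CCCO3)c1[C@H](OC(C)(C)C)C(=O)O`) gives 733 nm/s. Its close relative compound 2 (`Cc1nc2cc(-c3cccc(-c4ccccc4)c3)nn2c(-c2cc(F)c3c(c2C)CCCO3)c1C(OC(C)(C)C)C(=O)O`) gives 652 nm/s, and compound 3 (`Cc1nc2cc(-c3cccc(OCc4ccccc4)c3)nn2c(N2CCC(C)(C)CC2)c1C(OC(C)(C)C)C(=O)O`), which carries different groups on the shared core, gives 375 nm/s. Compound 1 therefore stands within the usual scatter of both others, so these numbers set no real order among the three.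

Compound 4 (`Cc1ccccc1-c1cccc(-c2cc3nc(C)c([C@H](OC(C)(C)C)C(=O)O)c(-c4cc(F)c5c(c4C)CCCO5)n3n2)c1`) departs from compound 1 at a single place: methyl in place of hydrogen on an aromatic carbon. In words, a methyl takes the place of a hydrogen on an aromatic carbon, ortho to a large group, turning phenyl into 2-methylphenyl.

Among the measured compounds shown here, only one measured step links close relatives: a 1.1-fold lower number from compound 1 to compound 2 (0.05 log units; within the scatter). It concerns (the fact that one of compounds 1 and 2 is drawn with a defined configuration and the other without, at the place where they differ), so it tests no added methyl and offers only indirect guidance. The data therefore give no measured size for this kind of change, and the value of compound 1, 733 nm/s, remains the best starting point. No shift beyond the scatter is expected, and the estimated step is a 1.0-fold lower number from compound 1 to compound 4 (0.02 log units; within the scatter). For compound 4 the expected value is 700 nm/s, with an estimated range from 380 nm/s to 1250 nm/s.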

Compound 4, apparent permeability: 471 nm/s
Estimate against measurement, compound 4: 1.5-fold (0.17 log units) above, within the range that was stated.
By their numbers in this assay, from the lowest: compounds 3, 4, 2 and 1 (each within the scatter of the next).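

Turning phenyl into 2-methylphenyl on compound 1 gives a 1.6-fold lower number from compound 1 to compound 4 (0.19 log units; within the scatter) in this assay, and this step lies within the scatter. Among the compounds shown here, a methyl can therefore sit on this aromatic carbon, ortho to a large group, without a shift that stands clear of the scatter in this read-out, whereas the only earlier step between close relatives concerned a drawn configuration and not an added group. The one fact available on these compounds deals with that configuration and offers no explanation for the number found with this added methyl.

This single step comes from one parent compound, so it cannot show whether the same methyl would behave alike on compound 3, which carries different groups on the shared core. It also leaves open whether other groups in this same place, such as an ethyl, a methoxy, a chlorine atom or an amine, would likewise stay within the scatter or would move the number clearly beyond it.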